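A few compounds are considered here, and "the series" means these few. Any claim that something is new, unique, unknown or untested is made for them only; others in the source may bear on it.

The series shares one core, carried by compound 1 `CCCCCCC(C)(O)CC(=O)O[C@H](CC=C(C)C)C1=CC(=O)c2c(O)ccc(O)c2C1=O`, compound 2 `CCCC(CC(=O)O[C@H](CC=C(C)C)C1=CC(=O)c2c(O)ccc(O)c2C1=O)OC(C)=O`, compound 3 `CCC(CO[C@H](CC=C(C)C)C1=CC(=O)c2c(O)ccc(O)c2C1=O)OC(C)=O` and the still unmeasured compound 4 `CC(C)=CC[C@@H](OC(=O)C1CCCOC1)C1=CC(=O)c2c(O)ccc(O)c2C1=O`. In a functional assay on HeLa cells (Homo sapiens) for cytotoxicity, read by MTT assay (on this read-out lower numbers stand for stronger inhibition and higher numbers for weaker inhibition), compound 1 gives only a limit, > 100000 nM. In this assay compound 2 gives 51200 nM, and compound 3 gives 44000 nM. Among the two numbers compound 2 stands highest, with compound 3 nearest, and the gap between them lies within the scatter; the one further value is the limit of > 100000 nM in this assay, at which 1 of the 3 values shown sits. Among the measured compounds shown here, the single measured step that touches the acyl side of the ester is an at least 1.9-fold lower number from compound 1 to compound 2 (0.29 log units; that floor lies within the scatter), and its floor lies within the scatter, so it offers no clear direction. oxan-3-yl in place of 2-acetoxypentyl on a carbonyl carbon The change from compound 2 to compound 4 thus puts oxan-3-yl in place of 2-acetoxypentyl on a carbonyl carbon whose other neighbour is oxygen next to a carbonyl group. For the measured compounds named here, no measured compound exchanges a chain for a ring at this place, so a step no larger than the scatter is expected, a 1.0-fold lower number from compound 2 to compound 4 (0.01 log units; within the scatter). Compound 4 is therefore estimated at 50000 nM, within 20000 nM to 120000 nM.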

Compound 4, half-maximal inhibitory concentration: 60500 nM
Estimate against measurement, compound 4: 1.2-fold (0.08 log units) below; low and high end bracket the measured number.
By their numbers in this assay, from the lowest: compounds 3, 2 and 4 (each within the scatter of the next). At a limit, above all of these: compound 1.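

Among the compounds shown here, the first exchange of a chain for a ring at this place, on a carbonyl carbon, gives a step within the scatter in this assay (a 1.2-fold higher number from compound 2 to compound 4 (0.07 log units; within the scatter)), so oxan-3-yl with its 6 heavy atoms and 2-acetoxypentyl with its 9 cannot be told apart here. The comparison with the other ester-bearing side chain also stays within the scatter (a 1.4-fold higher number from compound 3 to compound 4 (0.14 log units; within the scatter)), which places compounds 2, 3 and 4 together in this assay. The remaining step gives no direction (an at least 1.6-fold lower number from compound 1 to compound 4 (0.21 log units; that floor lies within the scatter)), and compound 1 stays a limit of the assay: the limit of > 100000 nM in this assay, at which 1 of the 4 values shown sits.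

From the compounds shown here alone, it remains open whether an amine or a carboxylic acid on the oxan-3-yl ring would separate from these compounds. Equally open, going by these compounds, is whether cyclohexyl, which lacks the ring oxygen, would do so at this carbonyl carbon.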